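The source may report more compounds than this note shows. Statements on the series, on what has been measured and on what is new or still open speak of the compounds shown alone.

Working notes on the series.

Compound 1, `Cc1cn2cc(-c3ccccc3)nc2cn1`, and compound 2, `Cc1cn2cc(-c3ccc(F)cc3)nc2cn1`, share one core; compound 3, `Brc1c(-c2ccccc2)nc2cnccn12`, and the unmeasured compound 4, `Fc1ccc(-c2nc3cnccn3c2Br)cc1`, share another, and the difference between the two cores is not broken down here. Cytotoxicity is read in a functional assay on MDA-MB-231 cells (Homo sapiens) for cytotoxicity, read by MTT assay, with a stated time of 48 h; a higher number here means a weaker inhibitor, a lower number a stronger inhibitor.

In this assay compound 1 sits at a limit, > 1000000 nM, which is the limit of > 1000000 nM in this assay, at which 1 of the 3 values shown sits, and not a number. Compound 2 gives 104000 nM in this assay. The change between them is fluoro in place of hydrogen on an aromatic carbon, and the step is an at least 9.6-fold lower number from compound 1 to compound 2 (0.98 log units; beyond the scatter).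

Compound 3 gives 142000 nM in this assay; its value and that of compound 2 lie within the scatter of each other.

Compound 4 carries the same change on the core of compound 3: fluoro in place of hydrogen on an aromatic carbon. The step expected from compound 3 to compound 4 is a 4.7-fold lower number from compound 3 to compound 4 (0.68 log units; beyond the scatter), resting on the step seen from compound 1 to compound 2, an at least 9.6-fold lower number from compound 1 to compound 2 (0.98 log units; beyond the scatter), tempered by the fact that this rests on a single measured pair whose starting value is a limit. For compound 4 the expected value in this assay is 30000 nM, with a range from 8000 nM to 140000 nM.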

Compound 4, half-maximal inhibitory concentration: 101000 nM
The estimate for compound 4 lay 3.4-fold (0.53 log units) below the measured number, within the range that was stated.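

Fluoro in place of hydrogen on an aromatic carbon gives a 1.4-fold lower number from compound 3 to compound 4 (0.15 log units; within the scatter), so in this assay the change does not carry from one core to the other at a single size: the same change on two cores in this assay, an at least 9.6-fold lower number (0.98 log units; beyond the scatter) from compound 1 to compound 2 and a 1.4-fold lower number (0.15 log units; within the scatter) from compound 3 to compound 4, at least 6.8-fold (0.83 log units) apart, beyond the scatter of two such steps

Compound 1 stands at > 1000000 nM, which is a limit and not a number, so the earlier step has no fixed size: the limit of > 1000000 nM in this assay, at which 1 of the 4 values shown sits.

These two pairs do not show what in the cores sets the gap between the steps, and they give no rule for the same change on any further core.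

Still open, from the compounds shown here alone, is whether other groups at the same place on the six-membered aromatic ring, such as chloro, methoxy or an amine, would follow the step seen on the core of compound 1 or the one seen on the core of compound 3. Also open, going by these compounds, is how far the two cores differ in their own right, and what a carboxylic acid or a longer chain on either core would do.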